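From Furan to Thiophene: What to Expect for Compound 4

A few compounds are considered here, and "the series" means these few. Any claim that something is new, unique, unknown or untested is made for them only; others in the source may bear on it.

Compound 1, `CCOC(=O)c1c(C)[nH]c(=O)c(C#N)c1-c1ccc(C)cc1`: in a functional assay on SK-OV-3 cells (Homo sapiens) for inhibition, read by MTT assay, with a stated time of 24 h (a lower number here means a stronger inhibitor, a higher number a weaker inhibitor), compound 1 gives > 100000 nM, which is a limit of the assay rather than a number.
Compound 2, `CCOC(=O)c1c(C)[nH]c(=O)c(C#N)c1-c1ccc(Br)cc1`: in this assay compound 2 gives > 100000 nM, again a limit.
Compound 3, `CCOC(=O)c1c(C)[nH]c(=O)c(C#N)c1-c1ccco1`: in this assay compound 3 gives 76000 nM.

Compound 3 therefore holds the only real number shown; the two other compounds sit at a limit (the limit of > 100000 nM in this assay, at which 2 of the 3 values shown sit). The steps that reach compound 3 are an at least 1.3-fold lower number from compound 1 to compound 3 (0.11 log units; that floor lies within the scatter) and an at least 1.3-fold lower number from compound 2 to compound 3 (0.11 log units; that floor lies within the scatter), and both are read only as floors, so they say little more than that compound 3 falls under that limit. The step between compound 1 and compound 2 is a step that the two limits leave unreadable from compound 1 to compound 2.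

Compound 4, `CCOC(=O)c1c(C)[nH]c(=O)c(C#N)c1-c1cccs1`, differs from compound 3 by thiophen-2-yl in place of furan-2-yl on an aromatic carbon. Among the compounds with values here, no measured step exchanges one five-membered ring for another, so the expectation rests on compound 3 alone. The expected step is a 1.2-fold lower number from compound 3 to compound 4 (0.07 log units; within the scatter), a change not beyond the usual scatter. Compound 4 is estimated at 65000 nM, with a range from 25000 nM to 160000 nM.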

Compound 4, half-maximal inhibitory concentration: 97300 nM
Beside the measured number, compound 4's estimate is 1.5-fold (0.18 log units) below it, within the range that was stated.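

Placing thiophen-2-yl where furan-2-yl stood, on the carbon opposite the ring nitrogen, leaves the two compounds within the scatter of each other in this assay (a 1.3-fold higher number from compound 3 to compound 4 (0.11 log units; within the scatter)). Within the data shown here, at this position, then, a sulfur in the five-membered ring in place of an oxygen makes no readable difference, which the earlier compounds could not show. The steps from the two substituted phenyl compounds are only floors (an at least 1.0-fold lower number from compound 2 to compound 4 (0.01 log units; that floor lies within the scatter) and an at least 1.0-fold lower number from compound 1 to compound 4 (0.01 log units; that floor lies within the scatter)), and they establish very little: the limit of > 100000 nM in this assay, at which 2 of the 4 values shown sit.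

As far as these compounds go, whether any group at this position can bring the number well under those of compound 3 and compound 4 stays open. A pyridin-3-yl ring or an amine here, or a carboxylic acid in place of the ethoxycarbonyl group, would be needed to address that.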